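Removing the methyl from the fused core of compound 1

The compounds below may be only part of what the source reports. "The series", "measured", "known", "first", "only" and "open" are said of these compounds alone.

Compound 1 `Cc1ccc2nc(NC(=O)/C=C/c3ccc(Cl)cc3)sc2c1` is measured in a functional assay on the whole organism (Hindlimb, strain albino) with Mus musculus as the target, in the maximal electroshock model, with a stated time of 0.5 h (a lower number here means that less compound is needed, a higher number that more compound is needed for the effect), and gives 152 umol/kg. Compound 2 `COc1ccc(/C=C/C(=O)Nc2nc3ccc(C)cc3s2)cc1` gives 209 umol/kg in this assay, and compound 3 `Cc1ccc2nc(NC(=O)/C=C/c3ccc(O)cc3)sc2c1` gives 271 umol/kg. Compound 1 has the lowest of the three numbers, but the steps to compound 2 and compound 3 are both within the scatter: a 1.4-fold higher number from compound 1 to compound 2 (0.14 log units; within the scatter) and a 1.8-fold higher number from compound 1 to compound 3 (0.25 log units; within the scatter). The third measured step, a 1.3-fold higher number from compound 2 to compound 3 (0.11 log units; within the scatter), is within the scatter as well.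

Compound 4 `O=C(/C=C/c1ccc(Cl)cc1)Nc1nc2ccccc2s1` differs from compound 1 in one place: hydrogen in place of methyl on an aromatic carbon. Among the compounds with values here, all three measured steps concern the aromatic ring at the far end of the acrylamide, not the fused core, so no measured step bears directly on this change. Within the data shown here, the only guidance is that every substitution seen so far has moved the number by less than the scatter. On that basis compound 4 is expected to stay close to compound 1, with a step of a 1.2-fold higher number from compound 1 to compound 4 (0.06 log units; within the scatter) in this assay that is not expected to exceed the scatter in either direction. The estimate for compound 4 in this assay is 175 umol/kg, with a range from 85 umol/kg to 360 umol/kg.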

Compound 4, dose for half-maximal effect: 367 umol/kg
Beside the measured number, compound 4's estimate is 2.1-fold (0.32 log units) below it; measured number above the stated range.
By their numbers in this assay, from the lowest: compounds 1, 2, 3 and 4 (each within the scatter of the next, the first and the last beyond it).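

Within the data shown here, the methyl on the core is the first place where a single change moves the number beyond the scatter: in this assay there is a 2.4-fold higher number from compound 1 to compound 4 (0.38 log units; beyond the scatter). The three earlier steps, all at the aromatic ring at the far end of the acrylamide, stayed within the scatter, so this step shows that the series is not insensitive to change everywhere, although the step here is modest. With the chloro group held fixed, the compound that keeps the methyl needs less compound for the effect, but nothing measured here explains why the loss of this single carbon has that result.

Among these compounds, the change is seen only in the pair carrying the chloro group, so it remains open whether removing the methyl has a step of similar size when the far ring carries a methoxy or hydroxy group instead. Also open, as far as these compounds go, is how this aromatic carbon of the core would respond to something other than methyl or hydrogen, such as an ethyl group, a fluorine atom or an amine.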